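The compounds below may be only part of what the source reports. "The series", "measured", "known", "first", "only" and "open" are said of these compounds alone.

For the measured compounds named here, in a functional assay on HCT-116 cells (Homo sapiens) for antiproliferative activity, read by MTT assay, with a stated time of 48 h (on this read-out higher numbers stand for weaker inhibition and lower numbers for stronger inhibition), compound 2 `COc1cc(N(Cc2ccc(F)cc2)C(=O)CSc2nc3ccccc3s2)cc(OC)c1OC` gives 59800 nM, the higher of the two numbers measured so far and therefore the weaker inhibition. Going by the values given here, the only comparison available is compound 1 `COc1ccc(CN(C(=O)CSc2nc3ccccc3s2)c2cc(OC)c(OC)c(OC)c2)cc1F`, which gives 1830 nM. These two differ in one place, a saturated chain carbon bound to an amide-type nitrogen, and putting 4-fluorophenyl in place of 3-fluoro-4-methoxyphenyl there produces a large step: a 33-fold higher number from compound 1 to compound 2 (1.51 log units; beyond the scatter). Compound 3 `COc1ccc(CN(C(=O)CSc2nc3ccccc3s2)c2cc(OC)c(OC)c(OC)c2)cc1N` has not yet been measured. It changes the same place, with 3-amino-4-methoxyphenyl in place of 4-fluorophenyl on a saturated chain carbon bound to an amide-type nitrogen. Among the compounds with values here, that single step is the only measured evidence bearing on this change. Compound 1, at 1830 nM, also carries a methoxy group on this ring, which compound 2 lacks, so a large move towards stronger inhibition is expected. Within the data shown here, no measured compound carries the amino group, so the size of that move remains uncertain. The expected change is a 46-fold lower number from compound 2 to compound 3 (1.66 log units; beyond the scatter). The estimated value for compound 3 is 1300 nM, with an expected range of 250 nM to 7000 nM.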

Compound 3, half-maximal inhibitory concentration: 491 nM
Estimate against measurement, compound 3: 2.6-fold (0.42 log units) above, and the stated range covers the measured number.
By their numbers in this assay, from the lowest: compound 3; then compound 1; then compound 2.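

In this assay, this position on a saturated chain carbon bound to an amide-type nitrogen proves highly sensitive to the group it carries: 3-amino-4-methoxyphenyl in place of 4-fluorophenyl gives a 120-fold lower number from compound 2 to compound 3 (2.09 log units; beyond the scatter). The methoxy group does not account for everything among these compounds, as compound 1 and compound 3 both carry it, yet amino in place of fluoro on an aromatic carbon still gives a 3.7-fold lower number from compound 1 to compound 3 (0.57 log units; beyond the scatter), a modest step but one beyond the scatter, so the second substituent on this ring also matters. No measurement shown here explains why either change alters the antiproliferative read-out.

The compounds shown do not separate the contribution of each group, so it remains open how a ring with the methoxy group alone or the amino group alone would compare with the 3-amino-4-methoxyphenyl of compound 3. Going by these compounds, it is also open whether the amino group itself is special, or whether a hydroxyl or dimethylamino group in its place would give a similarly low number.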